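The compounds below may be only part of what the source reports. "The series", "measured", "known", "first", "only" and "open" are said of these compounds alone.

Working notes on the series. Compound 1 `O=C(Nc1ccccc1)c1ccc(/N=N\c2c[nH]c3ccccc23)cc1` is the parent of the pair measured so far. In a functional assay on P388 cells (Mus musculus) for inhibition, read by MTT assay, with a stated time of 72 h (a higher number here means a weaker inhibitor, a lower number a stronger inhibitor), compound 1 is reported as "not active" (no number reported), so no single number stands for it and nothing can be placed on a scale. Compound 2 `O=C(Nc1ccccc1[N+](=O)[O-])c1ccc(/N=N\c2c[nH]c3ccccc23)cc1` is the other measured member; in this assay compound 2 gives 77900 nM, a weak figure. Among the compounds with values here, no step between two measured compounds is on record, so no counted step exists. Compound 3 `O=C(Nc1ccccc1Cl)c1ccc(/N=N\c2c[nH]c3ccccc23)cc1` is not yet measured. From compound 1 to compound 3 the change is chloro in place of hydrogen on an aromatic carbon. With compound 1 reported as "not active" (no number reported) and compound 2 at 77900 nM, the step from compound 1 to compound 3 in this assay is expected to be small, at most toward weak inhibition, with a real chance of no number at all. Compound 3 is expected at 100000 nM, in a range from 30000 nM to 300000 nM.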

Compound 3, half-maximal inhibitory concentration: "not active" (no number reported)
For compound 3 the study gives words and no number; the estimate stays without a comparison.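

In this assay compound 1 and compound 3 are both reported without a number, so no step can be read between them. The compounds shown leave open whether 2-chlorophenyl in place of phenyl shifts inhibition by any amount. No evidence bears on this result.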